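Thiazolidinone series: methoxy to chloro on the aryl ring

The compounds below may be only part of what the source reports. "The series", "measured", "known", "first", "only" and "open" are said of these compounds alone.

Measured compounds:
- compound 1, `COc1cccc(N2C(=O)CS/C2=N\c2csc(-c3ccccc3)c2)c1`: in a functional assay on MCF7 cells (Homo sapiens) for cytotoxicity, read by MTT assay, with a stated time of 72 h (on this read-out higher numbers stand for weaker inhibition and lower numbers for stronger inhibition), compound 1 gives "not determined" (no result reported)
- compound 2, `COc1ccc(-c2cc(/N=C3\SCC(=O)N3c3cccc(OC)c3)cs2)cc1`: in this assay compound 2 gives 1900 nM

Going by the values given here, compound 2 is the only compound of the series with a number; compound 1 carries no result, so there is no comparison to draw and no step between measured compounds is available. Compound 2 therefore stands alone, neither strong nor weak by any internal reference.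

Compound 3, `COc1cccc(N2C(=O)CS/C2=N\c2csc(-c3ccc(Cl)cc3)c2)c1`, keeps the shared core of compound 2 and differs in one place: chloro in place of methoxy on an aromatic carbon. Without a measured step of this kind in the series, there is no basis for expecting a shift beyond the usual scatter in either direction; a small move is possible but cannot be called.

The step from compound 2 to compound 3 is accordingly estimated as a 1.2-fold lower number from compound 2 to compound 3 (0.07 log units; within the scatter), a change that would not exceed the scatter. For compound 3 the estimate in this assay is 1600 nM, with a range from 500 nM to 5000 nM.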

Compound 3, half-maximal inhibitory concentration: > 50000 nM
Compound 3 ended at the assay's limit (the forecaster's own chance of this, stated with the estimate: 10%); middle value at least 31-fold (1.49 log units) from the limit.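

In this assay, the series now has its first readable change: on the six-membered aromatic ring of carbon only, para to a large group, going from 4-methoxyphenyl to 4-chlorophenyl gives an at least 26-fold higher number from compound 2 to compound 3 (1.42 log units; beyond the scatter), so this position is not indifferent to the group it carries. For compound 3, the entry > 50000 nM is a limit of the assay and not a number. The step is therefore open on one side, and its size rests on that limit: the limit of > 50000 nM in this assay, at which 1 of the 3 values shown sits.

Going by these compounds, whether the loss comes with the arrival of chloro or with the departure of methoxy stays open, as compound 1, with hydrogen at this place, gives "not determined" (no result reported) and offers no reference point. On these data alone, how an amine, a hydroxy group or a longer alkoxy chain would read at this position also remains open, as does whether the same sensitivity holds elsewhere on the shared core.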